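Swapping a Triazolylsulfanyl Arm for Isoquinolinyloxy

The compounds below may be only part of what the source reports. "The series", "measured", "known", "first", "only" and "open" are said of these compounds alone.

Compound 1 `CC(C)[C@H](NC(=O)COc1cccc2ccccc12)C(=O)N[C@@H](CC(=O)O)C(=O)CSc1nncn1C`: in a functional assay on Jurkat cells (Homo sapiens) for inhibition (on this read-out higher numbers stand for weaker inhibition and lower numbers for stronger inhibition), compound 1 gives > 200000 nM, a limit of the assay rather than a number.
Compound 2 `CC(C)[C@H](NC(=O)COc1cccc2ccccc12)C(=O)N[C@@H](CC(=O)O)C(=O)CSc1nnnn1-c1ccccc1`: in this assay compound 2 gives 153000 nM.
Compound 3 `Cc1cc(OCC(=O)[C@H](CC(=O)O)NC(=O)[C@@H](NC(=O)COc2cccc3ccccc23)C(C)C)nc(C)n1`: in this assay compound 3 gives > 200000 nM, also a limit of the assay.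

Compound 1 therefore stands at the edge of what this assay can read, and so does compound 3, since both sit at the limit of > 200000 nM in this assay, at which 2 of the 3 values shown sit; only compound 2 yields a measured number. Compound 4 `CC(C)[C@H](NC(=O)COc1cccc2ccccc12)C(=O)N[C@@H](CC(=O)O)C(=O)COc1nccc2ccccc12` differs from compound 1 by (isoquinolin-1-yl)oxy in place of (4-methyl-4H-1,2,4-triazol-3-yl)sulfanyl on a saturated chain carbon bound to a carbonyl carbon. Among the measured steps, an at least 1.3-fold lower number from compound 1 to compound 2 (0.11 log units; that floor lies within the scatter) stays within the scatter, and an at least 1.3-fold higher number from compound 2 to compound 3 (0.11 log units; that floor lies within the scatter) likewise. The closest in kind, exchanging the same sulfanyl-linked ring for an oxy-linked one, is a step that the two limits leave unreadable from compound 1 to compound 3, which the two limits leave unreadable. Among the measured compounds shown here, no step thus points to a change beyond the scatter, and a value near the limit seems likely. Compound 4 is expected to give 200000 nM, with a range from 60000 nM to 600000 nM, which amounts to an expected step of a number no higher from compound 1 to compound 4 (the limit leaves the size open).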

Compound 4, half-maximal inhibitory concentration: 106000 nM
For compound 4 the middle estimate is 1.9-fold (0.28 log units) above the measured one; the range from low to high includes it.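

With (isoquinolin-1-yl)oxy on the saturated chain carbon bound to a carbonyl carbon, compound 4 gives a measured number in this assay, which shows that an oxygen-linked arm at this place can be read, something compound 3 did not show. The steps to it are an at least 1.8-fold lower number from compound 1 to compound 4 (0.27 log units; that floor lies within the scatter) and an at least 1.8-fold lower number from compound 3 to compound 4 (0.27 log units; that floor lies within the scatter), and each gives only a floor, not a size: the limit of > 200000 nM in this assay, at which 2 of the 4 values shown sit.

Among the compounds shown here, the one step between two measured numbers is a 1.4-fold lower number from compound 2 to compound 4 (0.16 log units; within the scatter), so the arm of compound 4 cannot be told apart from the (1-phenyl-1H-tetrazol-5-yl)sulfanyl arm of compound 2.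

On these data alone, whether any arm at this place can move the number beyond the scatter stays open. So does what an amine or a carboxylic acid on the isoquinolin-1-yl ring would do.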